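Substituting the diallylamine arm of a corticotropin-releasing factor receptor ligand

The source may hold more compounds than are shown below. What is called first, only, known or untested is meant among the compounds shown, and "the series" means these compounds.

Of the compounds shown here, two of one shared core have been measured. Compound 1 `CCCN(CCC(F)(F)F)Cc1c(C(F)(F)F)nc2n(-c3c(C)cc(C)cc3C)c(Cl)cn12` gives 12 nM in an assay on cells for displacement of a labelled ligand from corticotropin-releasing factor receptor 1 (Homo sapiens), with a stated time of 100 min (on this read-out higher numbers stand for weaker inhibition and lower numbers for stronger inhibition), and compound 2 `C=CCN(CC=C)Cc1c(C(F)(F)F)nc2n(-c3c(C)cc(C)cc3C)c(Cl)cn12` gives 13 nM in this assay. The step of a 1.1-fold higher number from compound 1 to compound 2 (0.03 log units; within the scatter) means the two values sit within the scatter of each other, so compound 2 cannot be set above or below compound 1 on these numbers; it simply shares the same level of binding.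

Compound 3 `C=C(C)CN(CC)Cc1c(C(F)(F)F)nc2n(-c3c(C)cc(C)cc3C)c(Cl)cn12` carries ethyl(2-methylprop-2-en-1-yl)amino in place of diallylamino on a saturated chain carbon bound to an aromatic carbon. For the measured compounds named here, the only measured step that bears on this change is the one from compound 1 to compound 2, which swapped one pair of arms on the same amine nitrogen for another and moved the number by a 1.1-fold higher number from compound 1 to compound 2 (0.03 log units; within the scatter), that is, not beyond the scatter. Since the change to compound 3 again keeps the amine and exchanges only its two arms, with one double bond outside aromatic rings in place of two, the account expects no step beyond the scatter, a 1.1-fold higher number from compound 2 to compound 3 (0.03 log units; within the scatter), in this assay. Compound 3 is therefore estimated at 14 nM in this assay, with a range from 6 nM to 35 nM.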

Compound 3, inhibition constant: 67 nM
Compound 3: the middle estimate sits 4.8-fold (0.68 log units) below what was measured; measured number outside the range, above it.
By their numbers in this assay, from the lowest: compounds 1 and 2 (each within the scatter of the next); then compound 3.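

In this assay the arms on this amine nitrogen prove not to be freely interchangeable: ethyl(2-methylprop-2-en-1-yl)amino in place of diallylamino on a saturated chain carbon bound to an aromatic carbon gives a 5.2-fold higher number from compound 2 to compound 3 (0.71 log units; beyond the scatter) even though the two groups have the same heavy-atom count, neither has a ring, and the counted difference is one double bond outside aromatic rings. Set against propyl(3,3,3-trifluoropropyl)amino, the same group gives a 5.6-fold higher number from compound 1 to compound 3 (0.75 log units; beyond the scatter) and so places compound 3 apart from both earlier compounds, whereas the only earlier step, a 1.1-fold higher number from compound 1 to compound 2 (0.03 log units; within the scatter) and thus within the scatter, had shown no sensitivity to a change of arms here. No information is available that would explain this weaker inhibition, and no cause can be assigned to it.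

The change alters both arms at once, so the compounds shown do not separate the contribution of the ethyl arm from that of the 2-methylprop-2-en-1-yl arm. Also open, as far as these compounds go, is how the number would move with a cyclopropylmethyl arm on this nitrogen, or with a piperidine or morpholine ring in place of the two open arms.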